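Adding trifluoromethyl to compound 2

This account rests on a few compounds, and the source may have more. Where it says the series, first, only, none or still open, it means among the compounds named here.

Values in a functional assay on A2780 cells (Homo sapiens) for inhibition, read by sulforhodamine B assay; on this read-out higher numbers stand for weaker inhibition of growth and lower numbers for stronger inhibition of growth:
- Compound 1 (`FC(F)(F)c1ccc(-c2ccc(-c3ccc(-c4nc5ccccc5[nH]4)cc3)cc2)cc1`) gives 100000 nM
- Compound 2 (`Cc1ccc2[nH]c(-c3ccc(-c4ccc(-c5ccccc5)cc4)cc3)nc2c1`) gives 41200 nM

Compound 2 has the lower number of the two, and its gap to compound 1 lies beyond the usual scatter. Compound 3 (`Cc1ccc2[nH]c(-c3ccc(-c4ccc(-c5ccc(C(F)(F)F)cc5)cc4)cc3)nc2c1`) differs from compound 2 in one place: trifluoromethyl in place of hydrogen on an aromatic carbon, para to a large group. Within the data shown here, no measured pair shows this change alone. Among the measured compounds shown here, the only hint is compound 1 (100000 nM), which also carries trifluoromethyl but differs from compound 2 in another place as well. The estimated step in this assay is a 1.5-fold higher number from compound 2 to compound 3 (0.16 log units; within the scatter), an expected small rise toward weaker inhibition of growth that is not clearly beyond the scatter. Compound 3 is expected at about 60000 nM, with an estimated range of 22000 nM to 100000 nM.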

Compound 3, concentration for 50% growth inhibition: 12300 nM
Beside the measured number, compound 3's estimate is 4.9-fold (0.69 log units) above it; measured number outside the range, below it.
By their numbers in this assay, from the lowest: compound 3; then compound 2; then compound 1.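

Replacing phenyl with 4-(trifluoromethyl)phenyl gives a 3.3-fold lower number from compound 2 to compound 3 (0.52 log units; beyond the scatter) in this assay, a direct sign that this position accepts trifluoromethyl and that the change moves toward stronger inhibition of growth. With trifluoromethyl present in both compounds, methyl in place of hydrogen on an aromatic carbon gives an 8.1-fold lower number from compound 1 to compound 3 (0.91 log units; beyond the scatter), so the weak result for compound 1 cannot be read as an effect of trifluoromethyl alone. No measurement shown here explains why either change lowers the number.

Whether the two changes add up cannot be told, as no compound shown carries neither group alongside these. Going by these compounds, how a chlorine atom, a methoxy group or an amine would compare with trifluoromethyl at this position also remains open.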